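From fluoro to chloro: the step to compound 3

The source may hold more compounds than are shown below. What is called first, only, known or untested is meant among the compounds shown, and "the series" means these compounds.

- compound 1 `CN(C)C(=O)c1cc2cnc(Nc3ccc(NC(=O)C4(C(=O)Nc5ccc(F)cc5)CC4)cc3)nc2n1C1CCCC1`: 93.3%
- compound 2 `CN(C)C(=O)c1cc2cnc(Nc3ccc(N)cn3)nc2n1C1CCCC1`: 60.1%

In a functional assay on NCI-H1299 cells (Homo sapiens) for inhibition, read by CCK-8 assay, with a stated time of 72 h, tested at 1 uM (a lower number here means less inhibition of growth, a higher number more inhibition of growth at the concentration tested), compound 1 stands at 93.3%, the higher of the two measured values, and compound 2 at 60.1% lies lower, beyond the scatter. Compound 3 `CN(C)C(=O)c1cc2cnc(Nc3ccc(NC(=O)C4(C(=O)Nc5ccc(Cl)cc5)CC4)cc3)nc2n1C1CCCC1` has not yet been measured. It differs from compound 1 in one place, with chloro in place of fluoro on an aromatic carbon, para to a large group: chloro in place of fluoro on an aromatic carbon. Among the compounds with values here, no measured pair shows a change of this kind, so the data offer no direct guide. Compound 1 at 93.3% leaves little room upward in this assay, and no large fall is expected from this single exchange. The expected step of a number 1.3 percentage points lower from compound 1 to compound 3 (within the scatter) is estimated to stay within the scatter, with no clear direction. For compound 3 the estimated value is 92%, with an expected range from 80% to 99%.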

Compound 3, percent growth inhibition at one concentration: 52.2%
Estimate against measurement, compound 3: 39.8 percentage points above, and the stated range ends above it.
By their numbers in this assay, from the lowest: compounds 3 and 2 (each within the scatter of the next); then compound 1.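

In this assay chloro in place of fluoro on an aromatic carbon, para to a large group, gives a number 41.1 percentage points lower from compound 1 to compound 3 (beyond the scatter) as a large step from a single exchange. This position therefore responds strongly to the identity of one atom, with one heavy atom replacing one heavy atom and no hydrogen-bond donor or acceptor entering or leaving, which the earlier pair, differing in more than one place, could not show. No measurement shown here accounts for the size of this step.

As far as these compounds go, whether the fall belongs to chloro alone or extends to other groups at this place remains open, as bromo, methyl, methoxy or plain hydrogen could each fall closer to either compound 1 or compound 3. Also open, from the compounds shown here alone, is whether the same exchange would have a similar effect on another core.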